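Lengthening the Alkyne Chain on a Shared Core

The source may report more compounds than this note shows. Statements on the series, on what has been measured and on what is new or still open speak of the compounds shown alone.

Of the compounds shown here, three share one core and have been tested in a functional assay on HEL cells (Homo sapiens) for cytotoxicity; on this read-out higher numbers stand for lower toxicity in this test and lower numbers for higher toxicity in this test. Compound 1 `CCCCC#Cc1cc2cn(C)c(=O)nc2o1` carries a methyl on its aromatic nitrogen. In this assay compound 1 reaches only a limit of the assay, >= 217000 nM, so no number is known for it. Compound 2 `CCCCC#Cc1cc2cn([C@H]3C[C@H](O)[C@@H](CO)O3)c(=O)nc2o1` likewise gives only a limit, > 150000 nM, in this assay. Compound 3 `CCCCC#Cc1cc2cn([C@@H]3O[C@H](CO)[C@@H](O)[C@@H]3O)c(=O)nc2o1` also stops at a limit, > 144000 nM, in this assay. All three values are limits. The step that the two limits leave unreadable from compound 1 to compound 2 and the step that the two limits leave unreadable from compound 2 to compound 3 cannot be sized.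

Compound 4 `CCCCCCCCC#Cc1cc2cn(C)c(=O)nc2o1` differs from compound 1 at the alkyne chain: butyl in place of hydrogen on a saturated chain carbon, four bonds along the chain from a triple-bonded carbon. Among the measured compounds shown here, none of the measured steps touches this chain, so none of them bears directly on the change. What the measured compounds show is that alterations elsewhere on the core left all three at limits.

Compound 4 is therefore expected to behave like the others, with a step of an at least 1.2-fold lower number from compound 1 to compound 4 (0.08 log units; that floor lies within the scatter) that is expected to stay within the scatter. The estimate for compound 4 is 180000 nM, expected between 50000 nM and 400000 nM, most likely reported as a limit.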

Compound 4, minimum cytotoxic concentration: > 175000 nM
Compound 4: no number, only a limit; the forecaster's own chance of this, stated with the estimate: 75%; the middle value is on the limit's open side.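

Compound 1 and compound 4 both give only limits in this assay, so the step between them cannot be read. The compounds shown leave open whether adding butyl to the alkyne chain changes the toxicity in this test at all: none of them reaches an actual number.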